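Hydroxy in Place of Nitro on a Shared Core

The source may report more compounds than this note shows. Statements on the series, on what has been measured and on what is new or still open speak of the compounds shown alone.

Measured so far:
compound 1 `O=C1CSC(c2ccc(F)cc2)N1CCN1CCCCC1`, 100%
compound 2 `O=C1CSC(c2ccc([N+](=O)[O-])cc2)N1CCN1CCCCC1`, 100%

In an ADME assay on Vero cells (Chlorocebus sabaeus) for cytotoxicity, read by neutral red uptake, tested at 49 ug/mL (a lower number here means a stronger effect, a higher number a weaker effect of the compound at the concentration tested), compound 1 gives 100%. In this assay compound 2 gives 100%, which is level with compound 1 at the digits shown, within the scatter. For the measured compounds named here, the single recorded step is no change at the digits printed from compound 1 to compound 2 (within the scatter), a nitro in place of a fluoro on an aromatic carbon, and it moved nothing beyond the scatter.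

Compound 3 `O=C1CSC(c2ccc(O)cc2)N1CCN1CCCCC1` is the next step from compound 2. The change is hydroxy in place of nitro on an aromatic carbon. Going by the values given here, no measured step exchanges a nitro for a hydroxy, so the only guide is that the previous exchange at this same aromatic carbon left this assay unchanged, as seen in no change at the digits printed from compound 1 to compound 2 (within the scatter). On that basis the step of a number 2 percentage points lower from compound 2 to compound 3 (within the scatter) is expected to stay within the scatter. For compound 3 the estimated value in this assay is 98%, expected to fall between 85% and 105%.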

Compound 3, a percentage reported as activity, at one concentration (the size of the read-out at that concentration, not a potency): 96%
For compound 3 the middle estimate is 2 percentage points above the measured one; the range from low to high includes it.
By their numbers in this assay, from the lowest: compounds 3, 1 and 2 (each within the scatter of the next).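

In this assay the exchange of nitro for hydroxy on this aromatic carbon gives a number 4 percentage points lower from compound 2 to compound 3 (within the scatter) and the exchange of fluoro for hydroxy gives a number 4 percentage points lower from compound 1 to compound 3 (within the scatter) with the shared core unchanged. Hydroxy, which carries a hydrogen-bond donor where nitro has none, thus joins the groups tolerated at this place, para to a large group, and all three compounds stay level within the scatter. No measurement at hand bears on why this read-out stays level.

The compounds shown leave open whether an amine, a carboxylic acid or a longer chain on this same aromatic carbon would also stay level in this assay at the concentration tested. With a single concentration, they also leave open whether these groups would separate at higher concentrations.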